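The source may report more compounds than this note shows. Statements on the series, on what has been measured and on what is new or still open speak of the compounds shown alone.

Measured so far in an assay on cells for inhibition of HSP60/HSP10 (Homo sapiens), with a stated time of 60 min; a higher number here means a weaker inhibitor, a lower number a stronger inhibitor:
Compound 1 `O=S(=O)(Nc1ccc(-c2nc3cc(NS(=O)(=O)c4ccccc4O)ccc3o2)cc1)c1ccccc1O` gives 18000 nM.
Compound 2 `N#Cc1ccc(S(=O)(=O)Nc2ccc(-c3nc4cc(NS(=O)(=O)c5ccc(C#N)cc5)ccc4o3)cc2)cc1` gives 49000 nM.
Compound 3 `CCc1ccc(S(=O)(=O)Nc2ccc(-c3nc4ccccc4o3)cc2)cc1` gives only a limit of the assay, > 100000 nM.

Compound 1 holds the lowest number among the two values that are numbers, with compound 2 as its nearest neighbour at a gap that lies beyond the usual scatter. Compound 3 sits at the limit of the assay, one of the three values shown (the limit of > 100000 nM in this assay, at which 1 of the 3 values shown sits).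

The unmeasured compound 4 `O=S(=O)(Nc1ccc2oc(-c3ccccc3)nc2c1)c1ccccc1O` is reached from compound 1 by a single change: hydrogen in place of ((2-hydroxyphenyl)sulfonyl)amino on an aromatic carbon. The shared core stays, and only the arm on the phenyl ring is lost. For the measured compounds named here, no measured pair differs in just this way, so the size of the step is not known from the data. Compound 3, which also carries a single sulfonamide arm, reaches only the limit of the assay > 100000 nM, and that is the nearest pointer. The step is expected to weaken inhibition beyond the scatter, a 3.3-fold higher number from compound 1 to compound 4 (0.52 log units; beyond the scatter). For compound 4 the estimate in this assay is therefore 60000 nM, within a range from 20000 nM to 200000 nM, with a real chance that only a limit is reported.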

Compound 4, half-maximal inhibitory concentration: 85000 nM
Beside the measured number, compound 4's estimate is 1.4-fold (0.15 log units) below it; low and high end bracket the measured number.
By their numbers in this assay, from the lowest: compound 1; then compounds 2 and 4 (each within the scatter of the next). At a limit, above all of these: compound 3.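

In this assay, for the compounds shown here, taking away the ((2-hydroxyphenyl)sulfonyl)amino group gives the first direct reading of this position: a 4.7-fold higher number from compound 1 to compound 4 (0.67 log units; beyond the scatter). This arm, para to a large group, therefore adds to inhibition, but it is not essential for a measurable effect, and compound 4 still gives a number rather than a limit. Compound 3 remains the only compound at a limit of the assay: the limit of > 100000 nM in this assay, at which 1 of the 4 values shown sits.

Hydrogen is the only replacement shown at this place, so it remains open whether a smaller group, such as an amine or a methoxy group, would recover part of the lost inhibition. Also open, from the compounds shown here alone, is what removing the other sulfonamide arm would do, and whether a carboxylic acid could stand in for the hydroxyl group on the arm that stays.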